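Amide to Urea on a Pyrazole Inhibitor of Ovarian Cancer Cells

The compounds below may be only part of what the source reports. "The series", "measured", "known", "first", "only" and "open" are said of these compounds alone.

Measured compounds:
compound 1, `O=C(Nc1cccc(-n2cc(-c3ccncc3)c(-c3ccc(Cl)c(O)c3)n2)c1)Nc1cccc(C(F)(F)F)c1`, 1060 nM
compound 2, `COc1cc(-c2nn(-c3cccc(NC(=O)c4cccc(C(F)(F)F)c4)c3)cc2-c2ccncc2)ccc1Cl`, 1200 nM

In a functional assay on OVCAR-3 cells (Homo sapiens) for inhibition, read by sulforhodamine B assay, with a stated time of 48 h (on this read-out higher numbers stand for weaker inhibition of growth and lower numbers for stronger inhibition of growth), compound 2 gives 1200 nM, the highest of the two numbers recorded; its nearest neighbour is compound 1, which in this assay gives 1060 nM, a value within the scatter of compound 2, so the two cannot be ranked against each other.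

Compound 3, `COc1cc(-c2nn(-c3cccc(NC(=O)Nc4cccc(C(F)(F)F)c4)c3)cc2-c2ccncc2)ccc1Cl`, has not yet been tested. It differs from compound 2 in one place: (3-(trifluoromethyl)phenyl)amino in place of 3-(trifluoromethyl)phenyl on a carbonyl carbon. Compound 1 already carries this (3-(trifluoromethyl)phenyl)amino on its carbonyl carbon and sits within the scatter of compound 2, so the step from compound 2 to compound 3 is expected to be small, a 1.3-fold lower number from compound 2 to compound 3 (0.10 log units; within the scatter), with no clear direction beyond the scatter. Compound 3 is therefore estimated at 950 nM, in the range 350 nM to 2600 nM.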

Compound 3, concentration for 50% growth inhibition: 579 nM
Estimate against measurement, compound 3: 1.6-fold (0.22 log units) above, and the stated range covers the measured number.
By their numbers in this assay, from the lowest: compounds 3, 1 and 2 (each within the scatter of the next, the first and the last beyond it).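

In this assay, going by these compounds alone, putting (3-(trifluoromethyl)phenyl)amino in place of 3-(trifluoromethyl)phenyl on the carbonyl carbon gives a 2.1-fold lower number from compound 2 to compound 3 (0.32 log units; beyond the scatter), a modest change but the only step here that lies beyond the scatter, so this position does respond to the change from amide to urea. By contrast, methyl in place of hydrogen on the oxygen on an aromatic ring gives a 1.8-fold lower number from compound 1 to compound 3 (0.26 log units; within the scatter), which stays within the scatter and so cannot be read as a real change. Nothing available explains either step.

The compounds shown leave open whether a carbamate oxygen or a methylene in place of the amino nitrogen would give the same step, and whether a methyl on that nitrogen would keep it. They also leave open whether the step holds when a nitrile or a chlorine replaces the trifluoromethyl.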